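A cyclopentyl on the urea of compound 3

A few compounds are considered here, and "the series" means these few. Any claim that something is new, unique, unknown or untested is made for them only; others in the source may bear on it.

Compound 1 `O=C(Nc1ccc(-c2noc(-c3cccc(NS(=O)(=O)c4ccccc4)c3)n2)c(Cl)c1)c1cccnc1`: > 10000 nM
Compound 2 `O=C(Nc1ccc(-c2noc(-c3cccc(NS(=O)(=O)c4ccc(C(F)(F)F)cc4)c3)n2)c(Cl)c1)c1cccnc1`: > 10000 nM
Compound 3 `NC(=O)Nc1ccc(S(=O)(=O)Nc2cccc(-c3nc(-c4ccc(NC(=O)c5cccnc5)cc4Cl)no3)c2)cc1`: 2800 nM

Compound 3 is the only one of the three with a number in a functional assay on MDA-MB-231 cells (Homo sapiens) for antiproliferative activity, read by MTT assay, with a stated time of 72 h; a lower number here means a stronger inhibitor, a higher number a weaker inhibitor; compound 3 gives 2800 nM. For compound 1 the value in this assay is a limit of the assay, > 10000 nM. For compound 2 it is likewise a limit, > 10000 nM. The steps of an at least 3.5-fold lower number from compound 1 to compound 3 (0.55 log units; beyond the scatter) and an at least 3.5-fold lower number from compound 2 to compound 3 (0.55 log units; beyond the scatter) show the gain brought by the ureido, read against (the limit of > 10000 nM in this assay, at which 2 of the 3 values shown sit).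

Compound 4 `O=C(Nc1ccc(S(=O)(=O)Nc2cccc(-c3nc(-c4ccc(NC(=O)c5cccnc5)cc4Cl)no3)c2)cc1)NC1CCCC1` differs from compound 3 by cyclopentyl in place of hydrogen on an amide-type nitrogen. Within the data shown here, no measured step covers an alkyl on the urea nitrogen, so the expectation rests on the ureido series alone. Compound 4 is expected to give 1800 nM, between 500 nM and 6500 nM. The step is estimated as a 1.6-fold lower number from compound 3 to compound 4 (0.19 log units; within the scatter), at most a small change within the scatter.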

Compound 4, half-maximal inhibitory concentration: > 10000 nM
Compound 4 ended at the assay's limit; the forecaster's own chance of this, stated with the estimate: 10%; at least 5.5-fold (0.74 log units) between middle value and limit.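

Cyclopentyl in place of hydrogen on the amide-type nitrogen of the ureido gives an at least 3.5-fold higher number from compound 3 to compound 4 (0.55 log units; beyond the scatter) in this assay. The gain seen with the ureido therefore does not carry over to this substituted urea. Compound 4 sits at a limit of the assay, and its steps from compound 1 and compound 2 cannot be read: the limit of > 10000 nM in this assay, at which 3 of the 4 values shown sit.

Going by these compounds, it remains open whether methyl, or a chain ending in an amine or a carboxylic acid, on that nitrogen would keep the activity of compound 3. Also open, on these data alone, is whether the loss belongs to cyclopentyl alone or to any alkyl there.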